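Amino in place of hydrogen on the core of compound 1

This account rests on a few compounds, and the source may have more. Where it says the series, first, only, none or still open, it means among the compounds named here.

For the measured compounds named here, compound 1 `ClCc1ccc(Cn2cnc3c(Cl)ncnc32)cc1` holds the higher of the two numbers measured so far: in a functional assay on RXF 393 cells (Homo sapiens) for cytotoxicity, read by sulforhodamine B assay, with a stated time of 48 h (a higher number here means a weaker inhibitor of growth, a lower number a stronger inhibitor of growth), compound 1 gives 2300 nM. Compound 2 `ClCc1ccccc1Cn1cnc2c(Cl)nc(Cl)nc21` gives 100 nM in this assay, and the gap between these two values lies beyond the usual scatter. Compound 3 `Nc1nc(Cl)c2ncn(Cc3ccc(CCl)cc3)c2n1` differs from compound 1 by amino in place of hydrogen on an aromatic carbon. Going by the values given here, no comparable step among measured compounds exists, so the size of this change is open. The expected step is a 1.5-fold lower number from compound 1 to compound 3 (0.19 log units; within the scatter), a small lowering of the number, close to the scatter. Compound 3 is estimated at 1500 nM, within a range from 400 nM to 6000 nM.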

Compound 3, concentration for 50% growth inhibition: 1320 nM
Compound 3: middle estimate off by 1.1-fold (0.06 log units), on the high side; the measured number falls inside the stated range.
By their numbers in this assay, from the lowest: compound 2; then compounds 3 and 1 (each within the scatter of the next).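

Amino in place of hydrogen on this aromatic carbon, between two ring nitrogen atoms, gives a 1.7-fold lower number from compound 1 to compound 3 (0.24 log units; within the scatter) in this assay, so the position accepts this group without a change beyond the scatter. For the compounds shown here, this is the first reading of a one-place change, and it shows no measurable gain or loss from amino here. No available data explain this result.

Compound 2 differs from compound 3 in more than one place, so it does not inform this position. Going by these compounds, whether methylamino, dimethylamino or methoxy on this carbon would hold the number remains open.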